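The compounds below may be only part of what the source reports. "The series", "measured", "known", "first", "only" and "open" are said of these compounds alone.

Three compounds share one core and differ only in the chain on the amide-type nitrogen. In a functional assay for agonist activity at G protein-coupled receptor 88 (Homo sapiens), read by HTRF and cAMP accumulation (a higher number here means that more compound is needed for the effect, a lower number that less compound is needed), compound 1 `CC(C)C[C@H](N)CN(C(=O)[C@@H]1C[C@H]1c1ccccc1)c1ccc(-c2ccccc2)cc1` gives 880 nM, the highest of the two numbers that are known. Compound 2 `CC(C)CCCN(C(=O)[C@@H]1C[C@H]1c1ccccc1)c1ccc(-c2ccccc2)cc1` gives only a limit, > 100 nM. Because of that limit, a step that the limit leaves unreadable from compound 1 to compound 2. Compound 3 `N[C@@H](CC1CCCCC1)CN(C(=O)[C@@H]1C[C@H]1c1ccccc1)c1ccc(-c2ccccc2)cc1` gives 1.7 nM, and a 520-fold lower number from compound 1 to compound 3 (2.71 log units; beyond the scatter). Compound 4 `NC1(CN(C(=O)[C@@H]2C[C@H]2c2ccccc2)c2ccc(-c3ccccc3)cc2)CCCC1` has not been measured; it differs from compound 1 by 1-aminocyclopentyl in place of 1-amino-3-methylbutyl on a saturated chain carbon bound to an amide-type nitrogen. Going by the values given here, no measured step closes a ring at this carbon: the step to compound 3 changed a group further along the chain, and the step to compound 2 removed the amine, so neither transfers directly. Only a modest change is expected, a 1.8-fold lower number from compound 1 to compound 4 (0.25 log units; within the scatter). Compound 4 is therefore estimated at 500 nM, between 80 nM and 3000 nM.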

Compound 4, half-maximal effective concentration: 0.57 nM
Compound 4: middle estimate off by 880-fold (2.94 log units), on the high side; measured number outside the range, below it.
By their numbers in this assay, from the lowest: compound 4; then compound 3; then compound 1.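

On this saturated chain carbon bound to an amide-type nitrogen, tying the chain into a ring gives a 1500-fold lower number from compound 1 to compound 4 (3.19 log units; beyond the scatter) with no change in heavy-atom count, a gain the open-chain compounds gave no sign of. The ring also outdoes the 1-amino-2-cyclohexylethyl group, with a 3.0-fold lower number from compound 3 to compound 4 (0.47 log units; beyond the scatter) as a modest step, and the amine-free isopentyl chain, with an at least 170-fold lower number from compound 2 to compound 4 (2.24 log units; beyond the scatter) as a large one. That last step rests on a limit: the limit of > 100 nM in this assay, at which 1 of the 4 values shown sits.

Still open, from the compounds shown here alone, is whether 1-aminocyclobutyl or 1-aminocyclohexyl would serve as well. Also open, going by these compounds, is whether a plain cyclopentyl, without the amine, would keep this gain.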